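A Trifluoromethyl Swap on a Sulfonamide Without a Readable Number

The source may hold more compounds than are shown below. What is called first, only, known or untested is meant among the compounds shown, and "the series" means these compounds.

Compound 2 `C=Cc1ccc(S(=O)(=O)Nc2ccc(-c3nc4ccccc4o3)cc2)cc1` carries a 4-vinylphenyl group on the sulfonyl sulfur of the shared core. In an assay on isolated protein for inhibition of malate dehydrogenase, mitochondrial (Sus scrofa), with stated times of 45 min and 30 min (on this read-out lower numbers stand for stronger inhibition and higher numbers for weaker inhibition), compound 2 gives > 63000 nM, which is a limit of the assay rather than a number. Compound 1 `O=S(=O)(Nc1ccc(-c2nc3ccccc3o2)cc1)c1cccc(Cl)c1` differs only in having 3-chlorophenyl in that place. In this assay compound 1 gives > 63000 nM, also a limit. The step that the two limits leave unreadable from compound 1 to compound 2 cannot be read because of the limit of > 63000 nM in this assay, at which 2 of the 2 values shown sit. Compound 3 `O=S(=O)(Nc1ccc(-c2nc3ccccc3o2)cc1)c1ccc(C(F)(F)F)cc1` brings the change (trifluoromethyl in place of vinyl on an aromatic carbon). Among the compounds with values here, no measured step bears on this change; the one comparison available consists of two limits and shows no direction and no size. The step that the limit leaves unreadable from compound 2 to compound 3 is therefore expected to be none beyond the scatter. Compound 3 is estimated at 100000 nM, within 30000 nM to 400000 nM, and is expected most likely to be reported again only as a limit.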

Compound 3, half-maximal inhibitory concentration: > 63000 nM
Compound 3 gave a limit, no number (the forecaster's own chance of this, stated with the estimate: 85%); the middle value is on the limit's open side.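

The step from compound 2 to compound 3 cannot be read, since compound 2 and compound 3 both give a limit rather than a number: the limit of > 63000 nM in this assay, at which 3 of the 3 values shown sit.

The compounds shown leave open how compound 1, compound 2 and compound 3 truly compare, and whether any group in this place gives a measurable inhibition.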